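Estimating compound 3 from a single measured step

The source may report more compounds than this note shows. Statements on the series, on what has been measured and on what is new or still open speak of the compounds shown alone.

In a physicochemical assay for solubility, read by HPLC, in phosphate buffer, with a stated time of 24 h (on this read-out higher numbers stand for higher solubility and lower numbers for lower solubility), compound 1 `O=C(N/N=C/c1ccc(F)cc1)c1ccc(OCCOc2no[n+]([O-])c2S(=O)(=O)c2ccccc2)cc1O` gives 8.2 ug/mL and compound 2 `COc1cc(OCCOc2no[n+]([O-])c2S(=O)(=O)c2ccccc2)ccc1C(=O)N/N=C/c1ccc(F)cc1` gives 1.3 ug/mL as the lower of the two numbers. Compound 3 `COc1cc(OCCOc2no[n+]([O-])c2S(=O)(=O)c2ccccc2)ccc1/C(C)=N/N=C/c1ccc(F)cc1` has not been measured, and its change from compound 2 is a group of 12 heavy atoms (9 carbon, 2 nitrogen, 1 fluorine; one six-membered aromatic ring of carbon only) in place of a group of 12 heavy atoms (8 carbon, 2 nitrogen, 1 oxygen, 1 fluorine; one six-membered aromatic ring of carbon only), on an aromatic carbon on an aromatic carbon. For the measured compounds named here, the only measured step, a 6.3-fold lower number from compound 1 to compound 2 (0.80 log units; beyond the scatter) for methyl in place of hydrogen on an oxygen on an aromatic ring, is a different change and just a loose guide. A further downward move is therefore expected in this assay, an estimated 2.2-fold lower number from compound 2 to compound 3 (0.34 log units; beyond the scatter) in size. For compound 3 the expected value is 0.6 ug/mL with a likely range from 0.15 ug/mL to 2 ug/mL in this measurement.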

Compound 3, solubility: 2.4 ug/mL
Estimate against measurement, compound 3: 4.0-fold (0.60 log units) below; the whole stated range lies below it.
By their numbers in this assay, from the lowest: compounds 2 and 3 (each within the scatter of the next); then compound 1.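

In this assay the group on the aromatic carbon ortho to a methoxy group changes from one with 1 hydrogen-bond donor to one with 0 hydrogen-bond donors, which gives a 1.8-fold higher number from compound 2 to compound 3 (0.27 log units; within the scatter) and so leaves the two compounds indistinguishable. At this position, then, this exchange of an oxygen-bearing group for an all-carbon and nitrogen one makes no readable difference. Nothing measured here offers a reason for this result.

Still open, from the compounds shown here alone, is whether an amine or a carboxylic acid at this place would shift the number beyond the scatter.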